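The source may hold more compounds than are shown below. What is called first, only, known or untested is meant among the compounds shown, and "the series" means these compounds.

Compound 1 `CC(=O)Nc1ccc(O)c(C(=O)/C=C/c2ccccc2)c1` and compound 2 `COc1ccc(/C=C/C(=O)c2cc(NC(C)=O)ccc2O)cc1` share one core and differ only in one place, by methoxy in place of hydrogen on an aromatic carbon. In an ADME assay on THP-1 cells (Homo sapiens) for cytotoxicity, read by flow cytometry and propidium iodide staining, with a stated time of 72 h (a higher number here means a weaker inhibitor, a lower number a stronger inhibitor), compound 1 gives 85500 nM, and compound 2 gives 59200 nM. The step of a 1.4-fold lower number from compound 1 to compound 2 (0.16 log units; within the scatter) is therefore small, and the two numbers cannot be told apart with confidence.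

Compound 3 `COc1c(-c2ccccc2)oc2ccc(N)cc2c1=O` is built on a different core; how the two cores differ is not broken down here. In this assay compound 3 gives 74000 nM, which sits close to the value of compound 1 and, by a similarly small margin, close to that of compound 2, with no gap beyond the usual scatter among the three.

Compound 4 `COc1cccc(-c2oc3ccc(N)cc3c(=O)c2OC)c1` carries the same kind of change on the core of compound 3, namely (methoxy in place of hydrogen on an aromatic carbon). It is the same kind of change as that from compound 1 to compound 2, not the same: in compound 2 the methoxy stands para to a large group, whereas in compound 4 it stands meta to a large group.

For the measured compounds named here, the only precedent for adding a methoxy is the step of a 1.4-fold lower number from compound 1 to compound 2 (0.16 log units; within the scatter), which stayed within the scatter. On that basis the step from compound 3 to compound 4 is expected to be of about the same size, a 1.2-fold lower number from compound 3 to compound 4 (0.09 log units; within the scatter), in this assay. Compound 4 is therefore estimated at 60000 nM, with a likely range from 30000 nM to 120000 nM.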

Compound 4, half-maximal inhibitory concentration: 37000 nM
For compound 4 the middle estimate is 1.6-fold (0.21 log units) above the measured one, and the stated range covers the measured number.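

In this assay, methoxy in place of hydrogen on an aromatic carbon gives a 2.0-fold lower number from compound 3 to compound 4 (0.30 log units; within the scatter), so on this core too the step stays within the scatter. Set beside the earlier step, the two cores cannot be told apart in how they respond to this change: the same change on two cores in this assay, a 1.4-fold lower number (0.16 log units; within the scatter) from compound 1 to compound 2 and a 2.0-fold lower number (0.30 log units; within the scatter) from compound 3 to compound 4, 1.4-fold (0.14 log units) apart, within the scatter of two such steps. This shows that, in these two pairs, the change carries from one core to the other without any measurable difference between them, but it does not show that methoxy has a real effect of its own on either core, since neither step rises beyond the scatter, and two pairs cannot establish a rule for the series, particularly as the methoxy in compound 4 stands meta to a large group while the methoxy in compound 2 stands elsewhere.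

The compounds shown leave open whether the same methoxy would give a comparable step at other places on either core, so the role of placement remains unresolved. They also leave open whether a different group on the same aromatic carbon, such as a carboxylic acid, a fluorine atom or a longer chain like butoxy, would produce a step beyond the scatter on either core.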